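Removing a methyl group from a benzylamine tail

The source may hold more compounds than are shown below. What is called first, only, known or untested is meant among the compounds shown, and "the series" means these compounds.

Compound 1 `COc1cc(Oc2cccc(Nc3ccccc3)c2)cc(OC)c1CNCc1ccc(Br)cc1` was tested in a functional assay on HCT-15 cells (Homo sapiens) for inhibition, read by MTT assay, with a stated time of 72 h (a higher number here means a weaker inhibitor, a lower number a stronger inhibitor), where compound 1 gives 5410 nM. Compound 2 `COc1cc(Oc2cccc(Nc3ccccc3)c2)cc(OC)c1CNCc1ccc(C)cc1` differs from it only at one point on the outer ring, and in this assay compound 2 gives 5400 nM. The step of a 1.0-fold lower number from compound 1 to compound 2 (0.00 log units; within the scatter) shows that swapping these two groups changed nothing that can be told apart from run-to-run noise. For the measured compounds named here, on the two numbers measured so far, compound 2 therefore sits alongside compound 1, with no real gap between them.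

The next compound, compound 3 `COc1cc(Oc2cccc(Nc3ccccc3)c2)cc(OC)c1CNCc1ccccc1`, takes this one place a step further: hydrogen in place of methyl on an aromatic carbon. Going by the values given here, only one measured step bears on this position, the exchange from compound 1 to compound 2, and that step was flat. With two different groups at this spot giving the same reading, there is no sign that this spot controls the result, so no step beyond the scatter is expected in this assay either. For compound 3 the expected value is 5500 nM, with a likely range from 2500 nM to 12000 nM. This estimate amounts to an expected step of a 1.0-fold higher number from compound 2 to compound 3 (0.01 log units; within the scatter).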

Compound 3, half-maximal inhibitory concentration: 5020 nM
The estimate for compound 3 lay 1.1-fold (0.04 log units) above the measured number, and the stated range covers the measured number.
By their numbers in this assay, from the lowest: compounds 3, 2 and 1 (each within the scatter of the next).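

Until now this spot on the outer ring had been seen only carrying a group, either bromo or methyl; compound 3 shows what the reading does when hydrogen stands there instead, leaving a plain benzyl tail. In this assay losing the methyl gives (a 1.1-fold lower number from compound 2 to compound 3 (0.03 log units; within the scatter)) and losing the bromo gives (a 1.1-fold lower number from compound 1 to compound 3 (0.03 log units; within the scatter)), so neither change can be told apart from the ordinary spread of repeat measurements. Across these three compounds, then, having no added group at this spot reads the same as having either of the two groups, although nothing at hand explains why this position makes so little difference.

The compounds shown carry only hydrogen, bromo and methyl here, so it stays open whether a quite different group at this spot, such as a carboxylic acid, an amine or a longer chain, would leave the number just as flat. Every step also lies at this one place on the outer ring, so these compounds cannot tell whether changes elsewhere in the molecule would move the number.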